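This account rests on a few compounds, and the source may have more. Where it says the series, first, only, none or still open, it means among the compounds named here.

Working notes on the series, read in a functional assay on RS4-11 cells (Homo sapiens) for inhibition, read by CCK-8 assay, with a stated time of 72 h; a higher number here means a weaker inhibitor, a lower number a stronger inhibitor. Compound 1 (`COc1ccc(C2=C(CN3CCN(c4ccc(C(=O)NS(=O)(=O)c5ccc(NCC6CCOCC6)c([N+](=O)[O-])c5)c(Oc5cnc6[nH]ccc6c5)c4)CC3)CCC(C)(C)C2)cc1`) gives 12 nM. Among the compounds with values here, compound 2 (`CC1(C)CCC(CN2CCN(c3ccc(C(=O)NS(=O)(=O)c4ccc(NC5CCOC5)c([N+](=O)[O-])c4)c(Oc4cnc5[nH]ccc5c4)c3)CC2)=C(c2ccc(C(F)(F)F)cc2)C1`) gives 32 nM, the higher of the two numbers so far, and its gap to compound 1 lies beyond the scatter. These two compounds differ in more than one place, so the gap is not assigned to any one group.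

Compound 3 (`CCN1CCC(COc2ccc(S(=O)(=O)NC(=O)c3ccc(N4CCN(CC5=C(c6ccc(C(F)(F)F)cc6)CC(C)(C)CC5)CC4)cc3Oc3cnc4[nH]ccc4c3)cc2[N+](=O)[O-])CC1`) departs from compound 2 in a single place: (1-ethylpiperidin-4-yl)methoxy in place of (oxolan-3-yl)amino on an aromatic carbon. In words, (1-ethylpiperidin-4-yl)methoxy stands in place of (oxolan-3-yl)amino on an aromatic carbon, ortho to a nitro group and para to a large group.

Within the data shown here, no measured pair isolates a change at this place, so the data give no direct size for it. The expectation is therefore a small one, and it rests on little. The estimate amounts to a step of a 1.4-fold higher number from compound 2 to compound 3 (0.15 log units; within the scatter), expected to stay within the scatter and leaning towards a higher number. The range is kept wide to allow for a larger move in either direction. The estimated value for compound 3 is 45 nM, with an expected range of 12 nM to 170 nM.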

Compound 3, half-maximal inhibitory concentration: 4.9 nM
Compound 3: middle estimate off by 9.2-fold (0.96 log units), on the high side; measured number outside the range, below it.
By their numbers in this assay, from the lowest: compound 3; then compound 1; then compound 2.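

In this assay, the aromatic carbon ortho to a nitro group accepts a larger group without any loss: (1-ethylpiperidin-4-yl)methoxy in place of (oxolan-3-yl)amino gives a 6.5-fold lower number from compound 2 to compound 3 (0.81 log units; beyond the scatter), a step beyond the scatter. In this pair, the group rises from 6 to 10 heavy atoms, the five-membered non-aromatic ring gives way to a six-membered one, and the count of hydrogen-bond donors falls from 1 to 0, so the donor of the (oxolan-3-yl)amino group is not needed for a low number here. Nothing measured here bears on the origin of this step.

The ring, the ring hetero atom and the linking atom all change in this one step, so its size cannot be divided among them. On these data alone, a (1-ethylpiperidin-4-yl)methylamino group or an (oxan-4-yl)methoxy group on the same aromatic carbon would bear on that question, as would a piperidine with a hydrogen or a methyl in place of the ethyl, and the effect of each remains open.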